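Aromatic ring-bearing group replaces pyrrolidinyl on the shared core

The compounds below may be only part of what the source reports. "The series", "measured", "known", "first", "only" and "open" are said of these compounds alone.

Measured so far:
Compound 1, `COc1cc(C)c(C(=O)N=C(N)N)cc1S(C)(=O)=O`, 16 nM
Compound 2, `Cc1cc(N2CCCC2)c(S(C)(=O)=O)cc1C(=O)N=C(N)N`, 11 nM

In a functional assay for inhibition of sodium/hydrogen exchanger (Oryctolagus cuniculus) (on this read-out higher numbers stand for weaker inhibition and lower numbers for stronger inhibition), compound 2 gives the lowest of the two numbers, and its nearest neighbour is compound 1, whose number is higher by a margin that lies within the scatter of this assay, so the two cannot be told apart on these data. Among the measured compounds shown here, the only measured step, a 1.5-fold lower number from compound 1 to compound 2 (0.16 log units; within the scatter), swaps one group on an aromatic carbon for another and leaves the number essentially unchanged.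

Compound 3, `Cc1cc(-n2ccc(=O)cc2)c(S(C)(=O)=O)cc1C(=O)N=C(N)N`, has not yet been measured. It differs from compound 2 by a group of 7 heavy atoms (5 carbon, 1 nitrogen, 1 oxygen; one six-membered aromatic ring with 1 hetero atom) in place of a group of 5 heavy atoms (4 carbon, 1 nitrogen; one five-membered non-aromatic ring with 1 hetero atom), on an aromatic carbon. For the measured compounds named here, the one step on record bears on this change only in that it also exchanges a group at the same aromatic carbon, and that step was within the scatter. Going by the values given here, with no measured example of this entering group, the expectation for compound 3 is a step no larger than the scatter, perhaps a modest weakening, given as a 1.8-fold higher number from compound 2 to compound 3 (0.26 log units; within the scatter). The estimated value for compound 3 is 20 nM, with a range from 6 nM to 70 nM.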

Compound 3, half-maximal inhibitory concentration: 75 nM
Compound 3: the middle estimate sits 3.8-fold (0.57 log units) below what was measured, and the stated range ends below it.
By their numbers in this assay, from the lowest: compounds 2 and 1 (each within the scatter of the next); then compound 3.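

In this assay, the aromatic carbon ortho to a methylsulfonyl group proves sensitive to what it carries: the new group gives a 6.8-fold higher number from compound 2 to compound 3 (0.83 log units; beyond the scatter) and also a 4.7-fold higher number from compound 1 to compound 3 (0.67 log units; beyond the scatter). Methoxy and pyrrolidin-1-yl could not be told apart, so the apparent tolerance of this position holds only for those two groups and does not extend to the larger six-membered aromatic ring with its double bond outside the ring, which is the first group here to weaken inhibition beyond the scatter. Nothing available explains this loss of inhibition, so the result records the size of the change but not what drives it.

The compounds shown leave open which feature of the entering group matters, since ring size, aromatic character and the added carbonyl oxygen all change together in one step. Piperidin-1-yl would keep a saturated ring but enlarge it to six members, and phenyl or pyridin-3-yl would keep an aromatic ring without the carbonyl, so each would help show which of these changes goes with the weaker inhibition.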